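Notes on the step from 4-methoxyphenyl to 2-methoxyphenyl

The compounds below may be only part of what the source reports. "The series", "measured", "known", "first", "only" and "open" are said of these compounds alone.

Measured in an ADME assay on BHK cells (Mesocricetus auratus) for cytotoxicity, read by MTT assay; a lower number here means that less compound is tolerated, a higher number that more compound is tolerated:
- compound 1 `OC[C@@H]1[C@@H](O)[C@H](O)[C@@H](O)CN1CCCCCCOc1ccc(C(F)(F)F)cc1`: 470000 nM
- compound 2 `COc1ccc(OCCCCCCN2C[C@H](O)[C@@H](O)[C@H](O)[C@H]2CO)cc1`: > 500000 nM (a limit, not a number)
- compound 3 `OC[C@@H]1[C@@H](O)[C@H](O)[C@@H](O)CN1CCC#CCCOc1cc(F)ccc1F`: > 500000 nM (a limit, not a number)

Compound 2 has no exact position in the series. Its result is only a limit, > 500000 nM. Compound 3 is also reported only as a limit, > 500000 nM. The two therefore share (the limit of > 500000 nM in this assay, at which 2 of the 3 values shown sit), and no order can be read between them.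

Compound 4 `COc1ccccc1OCCCCCCN1C[C@H](O)[C@@H](O)[C@H](O)[C@H]1CO` has the same atoms as compound 2, joined differently: 2-methoxyphenyl in place of 4-methoxyphenyl on an oxygen on a saturated carbon. The change is 2-methoxyphenyl in place of 4-methoxyphenyl on an oxygen on a saturated carbon.

For the measured compounds named here, only one measured step offers any guidance, and it is an indirect guide, since it exchanges one group for another rather than placing the same group differently: an at least 1.0-fold higher number from compound 1 to compound 2 (0.02 log units; that floor lies within the scatter). Going by the values given here, no measured step covers the change to 2-methoxyphenyl itself.

Among the compounds with values here, with that step as the only guide, no change beyond the scatter is expected in this assay, and no direction can be assigned to the estimated step of a number no higher from compound 2 to compound 4 (the limit leaves the size open). For compound 4 the estimated value is 500000 nM, with an expected range of 250000 nM to 1000000 nM. A report of only a limit is also expected to be more likely than not.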

Compound 4, half-maximal cytotoxic concentration: > 500000 nM
Compound 4: no number, only a limit (the forecaster's own chance of this, stated with the estimate: 65%); the middle value lies on the limit itself.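

In this assay compound 4 gives > 500000 nM as a limit, not a number. Compound 2 is likewise reported only as a limit, so no step can be read between compound 2 and compound 4: the limit of > 500000 nM in this assay, at which 3 of the 4 values shown sit.

The compounds shown leave open whether 2-methoxyphenyl in place of 4-methoxyphenyl changes the tolerated concentration at all.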